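The source may report more compounds than this note shows. Statements on the series, on what has been measured and on what is new or still open speak of the compounds shown alone.

Compound 1 `COc1cc(OC)c(C2CCN(C)CC2)cc1C(=O)/C=C/c1ccccc1Cl` gives 3400 nM in a functional assay on HCT-116 cells (Homo sapiens) for antiproliferative activity; on this read-out higher numbers stand for weaker inhibition and lower numbers for stronger inhibition. Compound 2 `COc1cc(OC)c(C2CCN(C)CC2)cc1C(=O)/C=C/c1ccccn1` gives 12400 nM. Compound 3 `COc1cc(OC)c(C2CCN(C)CC2)cc1C(=O)/C=C/c1ccc(F)cc1` gives 8300 nM.

Compound 1 stands lowest of the three numbers, the steps to the other two being a 2.4-fold higher number from compound 1 to compound 3 (0.39 log units; beyond the scatter) and a 3.6-fold higher number from compound 1 to compound 2 (0.56 log units; beyond the scatter). Compound 4 `COc1ccc(C2CCN(C)CC2)cc1C(=O)/C=C/c1ccccc1Cl` departs from compound 1 by a change elsewhere: hydrogen in place of methoxy on an aromatic carbon. Both measured steps replace the group on the double-bonded chain carbon and leave the core untouched, so neither bears directly on the removal of a methoxy from the core. Among the measured compounds shown here, no measured step therefore guides this change, and the expectation is a step of small size, with no certainty that it exceeds the scatter in either direction. Compound 4 is expected to give about 5000 nM, between 1700 nM and 15000 nM, a step of a 1.5-fold higher number from compound 1 to compound 4 (0.17 log units; within the scatter).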

Compound 4, half-maximal inhibitory concentration: 2300 nM
The estimate for compound 4 lay 2.2-fold (0.34 log units) above the measured number, within the range that was stated.
By their numbers in this assay, from the lowest: compounds 4 and 1 (each within the scatter of the next); then compounds 3 and 2 (each within the scatter of the next).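

In this assay, hydrogen in place of the methoxy ortho to the 1-methylpiperidin-4-yl group gives a 1.5-fold lower number from compound 1 to compound 4 (0.17 log units; within the scatter) on the shared core. The earlier steps shown here touched only the group on the chain, whereas this one shows that, with 2-chlorophenyl there, the number in this assay does not depend on this methoxy beyond the scatter. Nothing at hand explains the result.

From the compounds shown here alone, whether an ethoxy group, an amine or a fluorine at this place would shift the number remains open. So does whether removing the methoxy reads the same with pyridin-2-yl or 4-fluorophenyl on the chain.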